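Fluoro in place of nitro on the benzyl ring

The source may hold more compounds than are shown below. What is called first, only, known or untested is meant among the compounds shown, and "the series" means these compounds.

Compound 3 (`Nn1c(SCc2ccc([N+](=O)[O-])cc2)nnc1-c1c[nH]c2ccccc12`) sits in the middle of the three numbers measured in a functional assay on MDA-MB-231 cells (Homo sapiens) for cytotoxicity, read by MTT assay, with a stated time of 72 h; a lower number here means a stronger inhibitor, a higher number a weaker inhibitor: compound 3 gives 740 nM, compound 2 (`Nn1c(SCc2cccc([N+](=O)[O-])c2)nnc1-c1c[nH]c2ccccc12`) gives 310 nM, and the unsubstituted parent compound 1 (`Nn1c(SCc2ccccc2)nnc1-c1c[nH]c2ccccc12`) gives 26500 nM. Both measured steps add a nitro group to the parent: an 85-fold lower number from compound 1 to compound 2 (1.93 log units; beyond the scatter) and a 36-fold lower number from compound 1 to compound 3 (1.55 log units; beyond the scatter).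

Compound 4 (`Nn1c(SCc2ccc(F)cc2)nnc1-c1c[nH]c2ccccc12`) differs from compound 3 by fluoro in place of nitro on an aromatic carbon. The step that bears on it is the one that introduced this same nitro group, a 36-fold lower number from compound 1 to compound 3 (1.55 log units; beyond the scatter); compound 4 undoes that change and leaves fluoro in its place. For the measured compounds named here, no measured compound carries fluoro, so how much of the loss of the nitro group is made up is not known from these data. The expected direction for compound 4 in this assay is therefore a higher number, with a step that is large but falls short of a full return to the number of compound 1, since compound 4 is not unsubstituted. Compound 4 is estimated at 8000 nM, with a range from 2000 nM to 30000 nM, which means an expected 11-fold higher number from compound 3 to compound 4 (1.03 log units; beyond the scatter).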

Compound 4, half-maximal inhibitory concentration: 1350 nM
For compound 4 the middle estimate is 5.9-fold (0.77 log units) above the measured one; the whole stated range lies above it.
By their numbers in this assay, from the lowest: compound 2; then compounds 3 and 4 (each within the scatter of the next); then compound 1.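

Working notes on the benzyl ring. In this assay, fluoro in place of nitro at this place, para to a large group, gives a 1.8-fold higher number from compound 3 to compound 4 (0.26 log units; within the scatter) and so stays within the scatter, which leaves compounds 3 and 4 indistinguishable in this assay despite the exchange of three heavy atoms and two hydrogen-bond acceptors for one heavy atom and none. Fluoro in place of hydrogen at the same carbon gives a 20-fold lower number from compound 1 to compound 4 (1.29 log units; beyond the scatter) and so lies beyond the scatter, which shows that the large step away from the parent at this position is not confined to nitro, the only group the earlier compounds showed there. No measurement at hand bears on why these two different groups give numbers so close together.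

Still open, as far as these compounds go, is whether an amine, a methoxy group or a carboxylic acid at this place would also match compounds 3 and 4 or would stay close to compound 1 at 26500 nM in this assay. Also open, from the compounds shown here alone, is whether fluoro on the ring carbon that carries nitro in compound 2 would give a number close to that of compound 2.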